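Swapping the Aryl Group: What to Expect for Compound 4

A few compounds are considered here, and "the series" means these few. Any claim that something is new, unique, unknown or untested is made for them only; others in the source may bear on it.

Three compounds share a common core and differ only in the aromatic ring attached to the carbon that is double-bonded to nitrogen. Compound 1 `O=C(CSc1nnc(-c2ccncc2)o1)N/N=C/c1ccc(Cl)cc1` gives 20500 nM in a functional assay on BGC-823 cells (Homo sapiens) for cytotoxicity, read by MTT assay, with a stated time of 48 h; a lower number here means a stronger inhibitor, a higher number a weaker inhibitor. Compound 2 `O=C(CSc1nnc(-c2ccncc2)o1)N/N=C/c1ccc([N+](=O)[O-])cc1` gives 31500 nM in this assay. Compound 3 `COc1cccc(/C=N/NC(=O)CSc2nnc(-c3ccncc3)o2)c1` gives 15800 nM in this assay, the lowest of the three numbers, but the steps leading to it are small: a 1.3-fold lower number from compound 1 to compound 3 (0.11 log units; within the scatter) and a 2.0-fold lower number from compound 2 to compound 3 (0.30 log units; within the scatter), and likewise a 1.5-fold higher number from compound 1 to compound 2 (0.19 log units; within the scatter). None of these changes moved the number beyond the scatter, so the three compounds cannot be ranked against one another.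

Compound 4 `O=C(CSc1nnc(-c2ccncc2)o1)N/N=C/c1cc(Br)ccc1O` differs from compound 3 by 5-bromo-2-hydroxyphenyl in place of 3-methoxyphenyl on a carbon with a double bond to nitrogen. Going by the values given here, no measured step involves this particular group, so the only guide is that every change at this position so far left the number where it was. On that basis, compound 4 is expected to show a step of a 1.0-fold higher number from compound 3 to compound 4 (0.01 log units; within the scatter) in this assay, meaning no change beyond the scatter. Compound 4 is therefore estimated at 16000 nM, with a range from 5000 nM to 50000 nM.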

Compound 4, half-maximal inhibitory concentration: 9590 nM
Beside the measured number, compound 4's estimate is 1.7-fold (0.22 log units) above it, and the stated range covers the measured number.
By their numbers in this assay, from the lowest: compounds 4, 3, 1 and 2 (each within the scatter of the next, the first and the last beyond it).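

Going by these compounds alone, with 5-bromo-2-hydroxyphenyl, the aromatic group on this carbon moves the number beyond the scatter for the first time in this assay with a 3.3-fold lower number from compound 2 to compound 4 (0.52 log units; beyond the scatter) and a 2.1-fold lower number from compound 1 to compound 4 (0.33 log units; beyond the scatter) as the two steps that show it, both modest in size. Set against 3-methoxyphenyl, the same group stays within the scatter, with a 1.6-fold lower number from compound 3 to compound 4 (0.22 log units; within the scatter) as the step, so compound 4 and compound 3 cannot be ranked against each other. No measurement shown here explains these steps.

The new group brings a bromine and a hydroxy group together, so the compounds shown cannot tell which of the two goes with the lower number. Also open, on these data alone, is whether a phenyl ring carrying only the bromine, only the hydroxy group, or an amine in place of the hydroxy group would give a similar number.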